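The source may hold more compounds than are shown below. What is called first, only, known or untested is meant among the compounds shown, and "the series" means these compounds.

Two compounds of the series carry numbers in a functional assay for inhibition, tested at 20 ug/mL; a higher number here means a stronger effect of the compound at the concentration tested, a lower number a weaker effect. Compound 1 `Cc1cc(O)c(C(C)C)cc1-c1cc(-c2ccccc2)c(C#N)c(=O)[nH]1` gives 22%, the lower of the two. Compound 2 `COc1cc(-c2cc(-c3cc(C(C)C)c(O)cc3C)[nH]c(=O)c2C#N)cc(OC)c1OC` gives 35%, higher than compound 1 by a margin beyond the usual scatter. Compound 3 `COc1cccc(-c2cc(-c3cc(C(C)C)c(O)cc3C)[nH]c(=O)c2C#N)c1` is not yet measured; it differs from compound 1 by methoxy in place of hydrogen on an aromatic carbon. Among the compounds with values here, no step between measured compounds that differ in one place is available to size this change. Given the value of compound 2, 35%, a step of a number 6 percentage points higher from compound 1 to compound 3 (within the scatter) is expected, upward but close to the scatter. Compound 3 is estimated at 28%, within 12% to 45%.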

Compound 3, a percentage reported as inhibition, at one concentration (the size of the read-out at that concentration, not a potency): 22%
Estimate against measurement, compound 3: 6 percentage points above; the measured number falls inside the stated range.
By their numbers in this assay, from the lowest: compounds 1 and 3 (each within the scatter of the next); then compound 2.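

In this assay, phenyl to 3-methoxyphenyl gives no change at the digits printed from compound 1 to compound 3 (within the scatter), the first single change sized in this series. At this place, meta to a large group, one methoxy therefore leaves the read-out at one concentration indistinguishable from that of the unsubstituted phenyl. No measured property bears on this result, so it carries no explanation.

Still open, going by these compounds, is whether an amine, a carboxylic acid or a longer alkoxy chain at this place would shift the read-out beyond the scatter. Methoxy on other carbons of this ring also remains unsized as a single change.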